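A few compounds are considered here, and "the series" means these few. Any claim that something is new, unique, unknown or untested is made for them only; others in the source may bear on it.

Measured so far:
- compound 2, `CCCCN(C(=O)c1ccc(C(F)(F)F)cc1)c1nnc(-c2cccc3[nH]ccc23)s1`: 63 uL/min
- compound 1, `CCCCN(C(=O)c1ccc(C(F)(F)F)cc1)c1nnc(-c2ccc(S(=O)(=O)NCCC(=O)O)cc2)s1`: 137 uL/min

Both compounds share the same core and differ only in the aromatic group attached to it. In an ADME assay on microsomes from liver (Mus musculus) for metabolic stability, read by LC-MS, tested at 0.5 uM (on this read-out lower numbers stand for slow clearance and higher numbers for fast clearance), compound 2 gives 63 uL/min, the lowest of the two numbers. Compound 1 gives 137 uL/min, a gap that lies beyond the usual scatter of this assay, so compound 2 is the slower-cleared of the pair. For the measured compounds named here, no pair of compounds here differs in a single place, so the two values show only where each compound stands, not what any one change does.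

Compound 3, `CCCCN(C(=O)c1ccc(C(F)(F)F)cc1)c1nnc(-c2ccc(F)c3[nH]ccc23)s1`, is the next compound and has not yet been measured. It differs from compound 2 in one place: fluoro in place of hydrogen on an aromatic carbon. Going by the values given here, nothing among the measured compounds shows what such a change does in this assay, so the expectation rests on compound 2 alone, with a step that is expected to stay within the scatter, leaning slightly lower. The step from compound 2 to compound 3 is estimated at a 1.3-fold lower number from compound 2 to compound 3 (0.10 log units; within the scatter). Compound 3 is therefore expected to give about 50 uL/min, with a range from 25 uL/min to 100 uL/min.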

Compound 3, intrinsic clearance in a liver preparation (reported as CLH), per the amount of preparation that the assay uses: 59.4 uL/min
For compound 3 the middle estimate is 1.2-fold (0.07 log units) below the measured one; measured number inside the range.
By their numbers in this assay, from the lowest: compounds 3 and 2 (each within the scatter of the next); then compound 1.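

In this assay, for the compounds shown here, the change of hydrogen to fluoro gives a 1.1-fold lower number from compound 2 to compound 3 (0.03 log units; within the scatter), the first single change that can be read. The carbon in question lies on the six-membered aromatic ring of the fused system, ortho to a fused ring, meta to a fused ring and para to a large group, and at this position the swap leaves two numbers that cannot be told apart, so a fluorine atom can sit here with no difference that this measurement can resolve. Nothing measured here explains this outcome, so the result records what was seen without saying why.

Going by these compounds, a single fluorine atom at one position says little about other groups there, so it remains open whether a chlorine atom, a methoxy group, a nitrile or an amine on the same carbon would give a number clearly apart from that of compound 2. On these data alone, it also remains open whether fluoro on another carbon of this ring, or a shorter or longer chain in place of the butyl chain on the shared core, would do so.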